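Trading a methyl for hydrogen on the aryl oxygen

The source may hold more compounds than are shown below. What is called first, only, known or untested is meant among the compounds shown, and "the series" means these compounds.

Compound 1, `O=C(Nc1cccc(-n2cc(-c3ccncc3)c(-c3ccc(Cl)c(O)c3)n2)c1)Nc1cccc(C(F)(F)F)c1`, gives 7350 nM in a functional assay on NCI-H226 cells (Homo sapiens) for inhibition, read by sulforhodamine B assay, with a stated time of 48 h; a higher number here means a weaker inhibitor of growth, a lower number a stronger inhibitor of growth.
Compound 2, `COc1cc(-c2nn(-c3cccc(NC(=O)c4cccc(C(F)(F)F)c4)c3)cc2-c2ccncc2)ccc1Cl`, gives 1660 nM.
Compound 3, `COc1cc(-c2nn(-c3cccc(NC(=O)Nc4ccc(Cl)c(Cl)c4)c3)cc2-c2ccncc2)ccc1Cl`, gives 1350 nM.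

In this assay, among the measured compounds shown here, compound 3 and compound 2 sit within the scatter of each other, the only measured step between them being a 1.2-fold lower number from compound 2 to compound 3 (0.09 log units; within the scatter). Compound 1 stands apart from both, with a number beyond the scatter above that of compound 3.

Compound 4, `O=C(Nc1cccc(-n2cc(-c3ccncc3)c(-c3ccc(Cl)c(O)c3)n2)c1)Nc1ccc(Cl)c(Cl)c1`, arises from compound 3 by hydrogen in place of methyl on an oxygen on an aromatic ring. For the measured compounds named here, no measured step makes exactly this change. Going by the values given here, the one measured compound carrying the hydroxy group, compound 1, also differs from compound 3 in the group on the urea, so its gap to compound 3 mixes two changes; the single change that is measured, on the carbonyl side, was within the scatter. With that, most of the gap between compound 1 and compound 3 is taken as belonging to the oxygen change, and a rise of about a 3.7-fold higher number from compound 3 to compound 4 (0.57 log units; beyond the scatter) is expected. Compound 4 is estimated at 5000 nM, within 1500 nM to 16000 nM.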

Compound 4, concentration for 50% growth inhibition: 1510 nM
Compound 4: middle estimate off by 3.3-fold (0.52 log units), on the high side; the measured number falls inside the stated range.
By their numbers in this assay, from the lowest: compounds 3, 4 and 2 (each within the scatter of the next); then compound 1.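

In this assay, methoxy and hydroxy on this aromatic ring cannot be told apart when 3,4-dichlorophenyl sits on the urea: the measured step is a 1.1-fold higher number from compound 3 to compound 4 (0.05 log units; within the scatter). The large gap that set compound 1 apart therefore does not follow the hydroxy group alone, since with the hydroxy group kept, 3,4-dichlorophenyl in place of 3-(trifluoromethyl)phenyl on an amide-type nitrogen gives a 4.9-fold lower number from compound 1 to compound 4 (0.69 log units; beyond the scatter). The effect of the oxygen change thus cannot be read from one urea partner and carried over to another.

Still open, on these data alone, is how a longer chain on this oxygen, such as ethoxy, or an amine in place of the hydroxy group would compare, and whether methoxy would match hydroxy with 3-(trifluoromethyl)phenyl on the urea. Nothing shown here gives a reason for either step.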